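A few compounds are considered here, and "the series" means these few. Any claim that something is new, unique, unknown or untested is made for them only; others in the source may bear on it.

- compound 1 `CCn1cc(-c2nc3ccccc3o2)c(=O)c2cc(F)c(Cl)cc21`: 28900 nM
- compound 2 `CCn1cc(-c2nc3ccccc3o2)c(=O)c2cc(F)c(N3CCN(C)CC3)cc21`: 2000 nM
- compound 3 `CCn1cc(-c2nc3ccccc3s2)c(=O)c2cc(F)c(N3CCNCC3)nc21`: 2400 nM

All values come from a functional assay on Bel-7402 cells (Homo sapiens) for cytotoxicity, read by MTT assay, with a stated time of 48 h; on this read-out higher numbers stand for weaker inhibition and lower numbers for stronger inhibition. Of these three, compound 1 has the highest number, 28900 nM.

Compound 4 `CCn1cc(-c2nc3ccc([N+](=O)[O-])cc3o2)c(=O)c2cc(F)c(Cl)cc21` is compound 1 with one change: nitro in place of hydrogen on an aromatic carbon. The nitro group replaces a hydrogen on an aromatic carbon.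

For the measured compounds named here, the only measured single-place step is a 14-fold lower number from compound 1 to compound 2 (1.16 log units; beyond the scatter). It replaces chloro with 4-methylpiperazin-1-yl, at a different site, so it says little about nitro in place of hydrogen. Going by the values given here, no measured step tests this change, and a large step is therefore not expected.

The estimated step is a 1.9-fold lower number from compound 1 to compound 4 (0.28 log units; within the scatter), so no clear shift is expected. Compound 4 is expected at 15000 nM, with an estimated range of 4000 nM to 50000 nM.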

Compound 4, half-maximal inhibitory concentration: 1800 nM
Compound 4: the middle estimate sits 8.3-fold (0.92 log units) above what was measured, and the stated range ends above it.
By their numbers in this assay, from the lowest: compounds 4, 2 and 3 (each within the scatter of the next); then compound 1.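

In this assay, nitro in place of hydrogen on the six-membered aromatic ring of carbon only gives a 16-fold lower number from compound 1 to compound 4 (1.21 log units; beyond the scatter). This position, which carries hydrogen in compounds 1, 2 and 3, therefore affects the read-out, and with chloro kept, a large step is possible without 4-methylpiperazin-1-yl. No available evidence bears on the reason for this step.

On these data alone, whether an amine or a carboxylic acid at this position gives a step of similar size remains open. So does whether nitro and 4-methylpiperazin-1-yl together go further than either alone.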